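Swapping a methyl ester for a benzyl ester

A few compounds are considered here, and "the series" means these few. Any claim that something is new, unique, unknown or untested is made for them only; others in the source may bear on it.

Compound 2 `COC(=O)/C=C/C1=CC[C@H]2C(C)(C)CCC[C@]2(C)[C@H]1C=O` stands at 21000 nM in a functional assay on A549 cells (Homo sapiens) for inhibition, read by MTT assay, with a stated time of 72 h (on this read-out higher numbers stand for weaker inhibition of growth and lower numbers for stronger inhibition of growth), and compound 3 `CCOC(=O)/C(C)=C/C1=CC[C@H]2C(C)(C)CCC[C@]2(C)[C@H]1C=O` at 26000 nM within the scatter of it, while compound 1 `CC1(C)CCC[C@]2(C)[C@@H](C=O)C(C=O)=CC[C@@H]12` stands higher at 90000 nM on this measure. Within the data shown here, the one measured step, a 4.3-fold lower number from compound 1 to compound 2 (0.63 log units; beyond the scatter) as a modest change, put 2-(methoxycarbonyl)ethenyl in place of formyl on a double-bonded ring carbon. Compound 4 `CC1(C)CCC[C@]2(C)[C@@H](C=O)C(/C=C/C(=O)OCc3ccccc3)=CC[C@@H]12` carries phenyl in place of hydrogen on a saturated chain carbon bound to an oxygen next to a carbonyl group with phenyl in place of hydrogen on a saturated chain carbon bound to an oxygen next to a carbonyl group, reading methyl to benzyl. Among the measured compounds shown here, no measured step changes this end alone. Compound 3, another ester, gives 26000 nM within the scatter of compound 2. No step beyond the scatter is therefore expected, and a 1.2-fold lower number from compound 2 to compound 4 (0.07 log units; within the scatter) is the estimated size. Compound 4 is estimated at 18000 nM with an expected range from 7000 nM to 45000 nM in this assay testing.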

Compound 4, concentration for 50% growth inhibition: 28000 nM
Beside the measured number, compound 4's estimate is 1.6-fold (0.19 log units) below it, and the stated range covers the measured number.
By their numbers in this assay, from the lowest: compounds 2, 3 and 4 (each within the scatter of the next); then compound 1.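

Methyl to benzyl, the first measured change at this place, gives a 1.3-fold higher number from compound 2 to compound 4 (0.12 log units; within the scatter) in this assay. Phenyl on a saturated chain carbon bound to an oxygen next to a carbonyl group is therefore accepted here, with no measurable difference in growth inhibition between the two esters. No available evidence bears on this result.

The compounds shown leave open whether a carboxylic acid or an amide in place of the ester would give a number beyond the scatter. They also leave open how a longer chain carrying the phenyl would read.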